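A few compounds are considered here, and "the series" means these few. Any claim that something is new, unique, unknown or untested is made for them only; others in the source may bear on it.

Compound 1 `CCc1ccc(-c2nc3ccccn3c2Sc2ccccc2)cc1`: 84500 nM
Compound 2 `c1ccc(Sc2c(-c3ccccc3)nc3ccc(-c4ccccc4)cn23)cc1`: 71700 nM

In a functional assay on DU-145 cells (Homo sapiens) for inhibition, read by MTT assay, with a stated time of 48 h (on this read-out lower numbers stand for stronger inhibition and higher numbers for weaker inhibition), compound 1 gives 84500 nM and compound 2 gives 71700 nM. Going by the values given here, these two values lie within the scatter of each other, so compound 1 stands level with the only other measured compound. Among the compounds with values here, the two differ in more than one place, and no measured pair isolates a single change.

The next compound to be tested is compound 3 `CSc1ccc(-c2nc3ccccn3c2Sc2ccccc2)cc1`. It keeps the core of compound 1 but carries methylsulfanyl in place of ethyl on an aromatic carbon, para to a large group, turning 4-ethylphenyl into 4-(methylsulfanyl)phenyl: methylsulfanyl in place of ethyl on an aromatic carbon. The data hold no direct measure of this change, so any expectation is loose. With compound 2 at 71700 nM, no step beyond the scatter is expected in this assay. The expected change, a 1.4-fold lower number from compound 1 to compound 3 (0.15 log units; within the scatter), is therefore small and leans slightly towards a lower number. For compound 3, the estimated value is 60000 nM, with an expected range from 25000 nM to 120000 nM.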

Compound 3, half-maximal inhibitory concentration: 52100 nM
The estimate for compound 3 lay 1.2-fold (0.06 log units) above the measured number; the measured number falls inside the stated range.
By their numbers in this assay, from the lowest: compounds 3, 2 and 1 (each within the scatter of the next).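

Going by these compounds alone, the exchange of ethyl for methylsulfanyl, on an aromatic carbon para to a large group, gives the first comparison in this set that isolates a single change: in this assay it amounts to a 1.6-fold lower number from compound 1 to compound 3 (0.21 log units; within the scatter). This position on the core of compound 1 therefore tolerates the replacement of one carbon of the substituent by sulfur, at an unchanged heavy-atom count, without a step that can be told apart from repeat measurement. Nothing available explains this outcome or ties it to any property of either group.

The compounds shown leave open whether any group at this position can move the number beyond the scatter, for example an amine, a carboxylic acid or a longer chain such as butyl, since ethyl and methylsulfanyl are the only two groups compared there. They also leave open whether the same exchange would give a similar result on the core of compound 2, which carries an added phenyl group and no substituent at the corresponding place.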